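From Compound 3 to Compound 4 in a Cell Toxicity Test

The source may hold more compounds than are shown below. What is called first, only, known or untested is meant among the compounds shown, and "the series" means these compounds.

Of the compounds shown here, three have been tested in a toxicity assay on THP-1 cells (Homo sapiens) for inhibition; a higher number here means that more compound is tolerated, a lower number that less compound is tolerated. Compound 1 `Cn1c(-c2ccc(C#N)cc2)cnc1NC(=O)c1ncc[nH]1` gives > 100000 nM, which is a limit of the assay rather than a number. Compound 2 `COc1ccc2nc(NC(=O)c3ccc(F)cc3)n(C)c2c1` likewise gives > 100000 nM, again a limit. Compound 3 `COc1ccc(-c2cnc(NC(=O)c3ccccc3OC)n2C)cc1` also gives > 100000 nM, a limit and not a measured value. So compound 3 stands exactly where every measured compound stands, namely at the limit of > 100000 nM in this assay, at which 3 of the 3 values shown sit. Within the data shown here, no two of the measured compounds differ from each other in a single place, so no step between them can be sized.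

Compound 4 `COc1ccc(-c2cnc(NC(=O)c3ccc(O)cc3)n2C)cc1` has not yet been tested in this assay. It differs from compound 3 in one place: 4-hydroxyphenyl in place of 2-methoxyphenyl on a carbonyl carbon.

Because all three measured values sit at the limit of > 100000 nM in this assay, at which 3 of the 3 values shown sit, the expected step of a number no higher from compound 3 to compound 4 (the limit leaves the size open) is none beyond the usual scatter. Compound 4 is therefore expected to give about 100000 nM, with a range from 50000 nM to 300000 nM, and the result will most likely again be reported only as a limit.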

Compound 4, half-maximal cytotoxic concentration: > 100000 nM
Compound 4: a limit, no number; the forecaster's own chance of this, stated with the estimate: 85%; the middle value sits exactly at the limit.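

In this assay compound 4 gives > 100000 nM, a limit and not a number. Among these compounds, compound 3 also stands at a limit, and no step from compound 3 to compound 4 can be read. The compounds shown leave open at what concentration, if any, each becomes toxic to these cells: the limit of > 100000 nM in this assay, at which 4 of the 4 values shown sit.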